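From 3-aminophenyl to 4-aminophenyl: compound 2 to compound 3

The source may report more compounds than this note shows. Statements on the series, on what has been measured and on what is new or still open speak of the compounds shown alone.

Among the compounds with values here, in a functional assay on MCF7 cells (Homo sapiens) for cytotoxicity, read by MTT assay, with a stated time of 96 h (a lower number here means a stronger inhibitor, a higher number a weaker inhibitor), compound 2 (`COc1cc(C(=O)c2cn(-c3cccc(N)c3)cc2-c2cccc(N)c2)cc(OC)c1OC`) gives 60 nM as the lower of the two numbers so far, and compound 1 (`COc1cc(C(=O)c2cn(-c3cccc(N)c3)cc2-c2cccc([N+](=O)[O-])c2)cc(OC)c1OC`) gives 510 nM in the same test. Compound 3 (`COc1cc(C(=O)c2cn(-c3cccc(N)c3)cc2-c2ccc(N)cc2)cc(OC)c1OC`) carries 4-aminophenyl in place of 3-aminophenyl on an aromatic carbon. Within the data shown here, the only measured step (an 8.5-fold lower number from compound 1 to compound 2 (0.93 log units; beyond the scatter)) is a modest one, amino in place of nitro, and it does not cover this change. No step beyond the scatter is expected in this assay and the expected step (a 1.2-fold lower number from compound 2 to compound 3 (0.08 log units; within the scatter)) has no favoured direction. For compound 3 the estimated value is 50 nM (expected range 12 nM to 250 nM).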

Compound 3, half-maximal inhibitory concentration: 14 nM
For compound 3 the middle estimate is 3.6-fold (0.55 log units) above the measured one; low and high end bracket the measured number.
By their numbers in this assay, from the lowest: compound 3; then compound 2; then compound 1.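

In this assay the place of the amino group on this aryl ring counts as well as its presence: 4-aminophenyl in place of 3-aminophenyl gives a 4.3-fold lower number from compound 2 to compound 3 (0.63 log units; beyond the scatter) even though the two groups hold the same atoms. Taken together with the loss of nitro, the change to 4-aminophenyl gives a 36-fold lower number from compound 1 to compound 3 (1.56 log units; beyond the scatter) and places compound 3 lowest of the three. No measured evidence accounts for this difference.

Whether the gain needs an amine at all remains open, as 4-hydroxyphenyl and 4-methoxyphenyl are not among the compounds shown. Also open, as far as these compounds go, is whether 4-aminophenyl would give a similar step in place of the other 3-aminophenyl group.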